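Swapping a small alkyl for a pyridylmethyl arm

The source may report more compounds than this note shows. Statements on the series, on what has been measured and on what is new or still open speak of the compounds shown alone.

Two compounds share one core and differ only in the group carried by the saturated chain carbon bound to an aromatic nitrogen. Compound 1 `O=C(O)c1cc(-c2ccc(-c3ccc(Cl)cc3Cl)cc2)n(Cc2cccnc2)n1` carries a pyridin-3-yl there. In an assay on isolated protein for inhibition of methionine--tRNA ligase, cytoplasmic (Homo sapiens) (on this read-out lower numbers stand for stronger inhibition and higher numbers for weaker inhibition), compound 1 reaches only a limit of the assay, > 100000 nM. Compound 2 `CCn1nc(C(=O)O)cc1-c1ccc(-c2ccc(Cl)cc2Cl)cc1` carries a methyl instead, and in this assay compound 2 gives 46400 nM, the only full number shown. The change an at least 2.1-fold lower number from compound 1 to compound 2 (0.33 log units; beyond the scatter) thus points the way: removing the pyridyl ring gave a lower number, a fact tied to the limit of > 100000 nM in this assay, at which 1 of the 2 values shown sits.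

Compound 3 `O=C(O)c1cc(-c2ccc(-c3ccc(Cl)cc3Cl)cc2)n(Cc2ccncc2)n1` takes the opposite direction, (pyridin-4-yl in place of methyl on a saturated chain carbon bound to an aromatic nitrogen). This largely reverses the change seen in the step from compound 1 to compound 2, save that the ring nitrogen sits at a different position, so a higher number is expected for compound 3, likely of a size comparable to that step, a 2.2-fold higher number from compound 2 to compound 3 (0.33 log units; beyond the scatter). The estimate for compound 3 in this assay is 100000 nM, within 40000 nM to 300000 nM, with a real chance that only a limit is reported.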

Compound 3, half-maximal inhibitory concentration: 26200 nM
Estimate against measurement, compound 3: 3.8-fold (0.58 log units) above; measured number below the stated range.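

In this assay, pyridin-4-yl in place of methyl on the saturated chain carbon bound to an aromatic nitrogen gives a 1.8-fold lower number from compound 2 to compound 3 (0.25 log units; within the scatter), so this read-out cannot tell the small alkyl group from the much larger aromatic ring. A ring at this place therefore does not by itself lead to a weaker result, and the position of the ring nitrogen makes a clear difference: pyridin-4-yl in place of pyridin-3-yl gives an at least 3.8-fold lower number from compound 1 to compound 3 (0.58 log units; beyond the scatter). The true size of that second step is unknown, as compound 1 gives only a limit of the assay and not a number: the limit of > 100000 nM in this assay, at which 1 of the 3 values shown sits.

From the compounds shown here alone, it remains open whether a plain phenyl ring or a pyridin-2-yl ring at this place would match pyridin-4-yl or pyridin-3-yl, which would show whether the ring nitrogen helps in one position or hinders in the other. Going by these compounds, it is also open whether an amine or a longer alkyl chain here could take the number beyond the scatter of the values for compound 2 and compound 3.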